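This account rests on a few compounds, and the source may have more. Where it says the series, first, only, none or still open, it means among the compounds named here.

Measured in a functional assay on THP-1 cells (Homo sapiens) for cytotoxicity, read by MTT assay, with a stated time of 72 h (on this read-out lower numbers stand for stronger inhibition and higher numbers for weaker inhibition), so far:
- compound 1 `C=C1C2=C(C(=O)N1OC)[C@H](OC(=O)CSc1nc3ccccc3o1)[C@@](C)(O)[C@H](CCCCC)O2` gives 2300 nM
- compound 2 `C=C1C2=C(C(=O)N1OC)[C@H](OC(=O)CSc1nc3ccccc3s1)[C@@](C)(O)[C@H](CCCCC)O2` gives 1600 nM

Compound 2, at 1600 nM in this pair, lies within the scatter of compound 1, so neither stands apart. The next compound is compound 3 `C=C1C2=C(C(=O)N1OC)[C@H](OC(=O)CCCCCl)[C@@](C)(O)[C@H](CCCCC)O2` and the change to it is 3-chloropropyl in place of (1,3-benzothiazol-2-yl)sulfanyl on a saturated chain carbon bound to a carbonyl carbon in full. In words, 3-chloropropyl stands in place of (1,3-benzothiazol-2-yl)sulfanyl on a saturated chain carbon bound to a carbonyl carbon.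

For the measured compounds named here, only one measured step bears on this change, and only weakly. That step is a 1.4-fold lower number from compound 1 to compound 2 (0.16 log units; within the scatter) and it exchanges 1,3-benzoxazol-2-yl for 1,3-benzothiazol-2-yl on a sulfur. Going by the values given here, it shows that this exchange left the number within the scatter, but no compound without the ring-bearing group has been measured. The size of the coming change in this assay is therefore poorly constrained. A modest move to a higher number is expected, held with little confidence, and the estimated step is a 2.2-fold higher number from compound 2 to compound 3 (0.34 log units; beyond the scatter) on that basis.

For compound 3 the expected value is 3500 nM with an estimated range from 1200 nM to 10000 nM in this read-out.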

Compound 3, half-maximal inhibitory concentration: 4600 nM
Beside the measured number, compound 3's estimate is 1.3-fold (0.12 log units) below it; low and high end bracket the measured number.
By their numbers in this assay, from the lowest: compounds 2, 1 and 3 (each within the scatter of the next, the first and the last beyond it).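

In this assay, the earlier pair only swapped one fused ring for another on the sulfur, whereas this change removes the whole ring-bearing group and leaves 3-chloropropyl, which has no ring, on the saturated chain carbon bound to a carbonyl carbon. For the compounds shown here, that exchange gives a 2.9-fold higher number from compound 2 to compound 3 (0.46 log units; beyond the scatter) and so is the first step to pass the usual scatter, though only modestly. Going by these compounds alone, the same exchange made against the benzoxazole-bearing group gives a 2.0-fold higher number from compound 1 to compound 3 (0.30 log units; within the scatter) and stays within the scatter, so the chain is separated from only one of the two ring-bearing groups, and a simple chain at this position keeps cytotoxicity in the same general range as those two compounds. No supporting measurement is available to explain the step.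

The compounds shown leave open whether the terminal chlorine matters at all, as a plain butyl chain, a terminal amine or a carboxylic acid at the chain end would test this directly. They also leave open whether a longer chain would bring the number closer to that of the ring-bearing compounds, or whether these small differences hold on cells other than these.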